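Hydroxy for chloro on two related cores

A few compounds are considered here, and "the series" means these few. Any claim that something is new, unique, unknown or untested is made for them only; others in the source may bear on it.

Measured so far in a functional assay, read by Griess assay, with a stated time of 2.5 h; on this read-out lower numbers stand for stronger inhibition and higher numbers for weaker inhibition:
compound 1 `COc1cc(OC)c(-c2cc(=O)c3cc(Cl)ccc3o2)cc1OC` gives 2.15 ug/mL;
compound 2 `COc1cc(OC)c(OC)cc1/C=C/C(=O)c1cc(Cl)ccc1O` gives 2.32 ug/mL;
compound 3 `COc1cc(OC)c(OC)cc1/C=C/C(=O)c1cc(O)ccc1O` gives 2.44 ug/mL.

Compound 1 stands at the lowest of the three numbers, with compound 2 nearest and compound 3 furthest, but all three lie within the scatter of one another. Compound 3 differs from compound 2 by one change hydroxy in place of chloro on an aromatic carbon and the result was a 1.1-fold higher number from compound 2 to compound 3 (0.02 log units; within the scatter) in this assay. Compound 4 `COc1cc(OC)c(-c2cc(=O)c3cc(O)ccc3o2)cc1OC` is not yet measured. It differs from compound 1 by hydroxy in place of chloro on an aromatic carbon. How the core of compound 1 differs from that of compound 2 is not broken down here. The surroundings of the change are not identical: in compound 2 the carbon is meta to a large group and para to a hydroxy group, while in compound 1 it is part of a fused or bridged system of two rings, meta to a fused ring and para to a fused ring; it is the same kind of change, not the same. Resting on compound 2 and compound 3, the step from compound 1 to compound 4 is expected to be a 1.1-fold higher number from compound 1 to compound 4 (0.03 log units; within the scatter). For compound 4 in this assay the estimate is 2.3 ug/mL, expected between 1.2 ug/mL and 4.5 ug/mL.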

Compound 4, half-maximal inhibitory concentration: 2.14 ug/mL
Compound 4: the middle estimate sits 1.1-fold (0.03 log units) above what was measured; low and high end bracket the measured number.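

In this assay, hydroxy in place of chloro on an aromatic carbon gave a 1.0-fold lower number from compound 1 to compound 4 (0.00 log units; within the scatter). Set beside the same change on the other core, the two steps agree: the same change on two cores in this assay, a 1.1-fold higher number (0.02 log units; within the scatter) from compound 2 to compound 3 and a 1.0-fold lower number (0.00 log units; within the scatter) from compound 1 to compound 4, 1.1-fold (0.02 log units) apart, within the scatter of two such steps. This shows that, for these two pairs, the change carries from one core to the other with the number staying within the scatter on both, but it does not show that the same would hold on any further core or in another assay.

The compounds shown carry only chloro or hydroxy at this place, so what an amine or a carboxylic acid would do there remains open. The methoxy groups are also the same throughout, which leaves open the effect of a longer chain in their stead.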